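A few compounds are considered here, and "the series" means these few. Any claim that something is new, unique, unknown or untested is made for them only; others in the source may bear on it.

In a physicochemical assay for permeability, using PAMPA (a higher number here means that the compound crosses the layer faster, a lower number that the compound crosses the layer more slowly), compound 2 `Cc1oc(-c2c(Cl)cccc2Cl)nc1CN1CCC(C(=O)NCCCN2C[C@H](C)C[C@H](C)C2)CC1` stands as "not determined" (no result reported); the shared core is the same as in compound 1 `Cc1ccccc1-c1nc(CN2CCC(C(=O)NCCCN3CCC(C)CC3)CC2)c(C)o1`, which in this assay gives 425 10^-6 cm/s, and in compound 3 `Cc1ccccc1-c1nc(CN2CCC(C(=O)N3CCN(CCN(C)C)CC3)CC2)c(C)o1`, which gives 14 10^-6 cm/s. The change from compound 2 to compound 4 `CCc1ccccc1-c1nc(CN2CCC(C(=O)NCCCN3C[C@H](C)C[C@H](C)C3)CC2)c(C)o1` is 2-ethylphenyl in place of 2,6-dichlorophenyl on an aromatic carbon. Within the data shown here, the only measured step, a 30-fold lower number from compound 1 to compound 3 (1.48 log units; beyond the scatter), concerns the group on the carbonyl carbon and not the aromatic ring, so it does not bear on this change. Compound 4 carries the same kind of amide chain as compound 1, so no step beyond the scatter away from that level is expected. Compound 4 is therefore estimated at 400 10^-6 cm/s, with a range from 150 10^-6 cm/s to 900 10^-6 cm/s.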

Compound 4, apparent permeability: 106 10^-6 cm/s
The estimate for compound 4 lay 3.8-fold (0.58 log units) above the measured number; measured number outside the range, below it.
By their numbers in this assay, from the lowest: compound 3; then compound 4; then compound 1.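

No new step can be read from compound 2 to compound 4 in this assay. The compounds shown leave open what 2-ethylphenyl in place of 2,6-dichlorophenyl does to the number. Nothing available bears on this result.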